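Swapping a benzyl arm for a hydroxyethyl group

A few compounds are considered here, and "the series" means these few. Any claim that something is new, unique, unknown or untested is made for them only; others in the source may bear on it.

Two compounds sharing one core were tested in a toxicity assay on MDCK cells (Canis lupus familiaris) for cytotoxicity, read by crystal violet staining, with a stated time of 48 h; on this read-out higher numbers stand for lower toxicity in this test and lower numbers for higher toxicity in this test. Compound 1 `Cc1ccc2cc(CNCc3ccc(F)cc3)c(=O)[nH]c2c1` gives only a limit there, > 33000 nM. Compound 2 `Cc1ccc2[nH]c(=O)c(CN(Cc3ccc(OC(C)C)cc3)Cc3ccc(C(C)(C)C)cc3)cc2c1` likewise gives only a limit in this assay, > 5000 nM, so its toxicity is not pinned to a number. Compound 3 `Cc1ccc2[nH]c(=O)c(CN(Cc3ccc(C(C)(C)C)cc3)[C@H](CO)c3ccccc3)cc2c1` is not yet measured; it differs from compound 2 by 2-hydroxy-1-phenylethyl in place of 4-isopropoxybenzyl on an amine nitrogen. With nothing but limits in hand, the step in this assay is expected to stay within the scatter, a step that the limit leaves unreadable from compound 2 to compound 3. Compound 3 is therefore estimated at 20000 nM, with a range from 5000 nM to 80000 nM, most likely reported as another limit.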

Compound 3, half-maximal cytotoxic concentration: > 10000 nM
Compound 3 was reported as a limit; the forecaster's own chance of this, stated with the estimate: 70%; the middle value is on the limit's open side.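

For the compounds shown here, compound 2 and compound 3 both give only limits, so no step between them can be read. The compounds shown leave open at what concentration any of the three becomes toxic.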